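The compounds below may be only part of what the source reports. "The series", "measured", "known", "first", "only" and "open" are said of these compounds alone.

Compound 1 `Fc1ccc(NC(=S)N/N=C\c2ccnc3ccccc23)cc1`: 1070 nM
Compound 2 `O=[N+]([O-])c1ccc(NC(=S)N/N=C\c2ccnc3ccccc23)cc1`: 1330 nM
Compound 3 `S=C(N/N=C\c1ccnc2ccccc12)Nc1cccnc1`: 1100 nM

In a functional assay on T47D cells (Homo sapiens) for cytotoxicity, read by MTT assay, with a stated time of 48 h (a lower number here means a stronger inhibitor, a higher number a weaker inhibitor), compound 1 gives the lowest of these three numbers, yet the steps of a 1.2-fold higher number from compound 1 to compound 2 (0.09 log units; within the scatter) and a 1.0-fold higher number from compound 1 to compound 3 (0.01 log units; within the scatter) both stay within the scatter, so the three compounds cannot really be told apart. Compound 4 `Cc1ccc(NC(=S)N/N=C\c2ccnc3ccccc23)cc1` differs from compound 1 in one place: methyl in place of fluoro on an aromatic carbon. The step from compound 1 to compound 2 bears most directly on this change: it also swapped the fluoro on that aromatic carbon, there for nitro, and the number moved only within the scatter. The step from compound 1 to compound 3 put pyridin-3-yl in place of 4-fluorophenyl and likewise stayed within the scatter. For compound 4 the expected step is therefore a 1.0-fold higher number from compound 1 to compound 4 (0.01 log units; within the scatter), nothing beyond the scatter. Compound 4 is estimated at 1100 nM, with a range from 600 nM to 2100 nM.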

Compound 4, half-maximal inhibitory concentration: 1320 nM
For compound 4 the middle estimate is 1.2-fold (0.08 log units) below the measured one; low and high end bracket the measured number.
By their numbers in this assay, from the lowest: compounds 1, 3, 4 and 2 (each within the scatter of the next).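

In this assay, the aromatic carbon para to a large group now carries fluoro, nitro or methyl with no readable difference: a 1.2-fold higher number from compound 1 to compound 4 (0.09 log units; within the scatter) and a 1.0-fold lower number from compound 2 to compound 4 (0.00 log units; within the scatter) both stay within the scatter. Putting 4-methylphenyl in place of pyridin-3-yl also leaves the number within the scatter, as a 1.2-fold higher number from compound 3 to compound 4 (0.08 log units; within the scatter) shows. So a plain carbon group at this position gives a number that cannot be told apart from those of the fluoro and nitro compounds. On these data alone, whether an amine, a carboxylic acid or a longer chain at this position would move the number beyond the scatter stays open. No measurement shown explains why these groups read alike.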